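A few compounds are considered here, and "the series" means these few. Any claim that something is new, unique, unknown or untested is made for them only; others in the source may bear on it.

Measured so far in a toxicity assay on MCF-10A cells (Homo sapiens) for cytotoxicity, read by MTT assay, with a stated time of 48 h; on this read-out lower numbers stand for stronger inhibition and higher numbers for weaker inhibition:
- compound 2 `Cc1ccc(C(=O)/C=C/c2ccc3c(c2)B(O)OC3)cc1` gives 8300 nM
- compound 1 `O=C(/C=C/c1ccc2c(c1)B(O)OC2)c1ccc(I)cc1` gives only a limit, > 100000 nM

Going by the values given here, compound 2 thus holds the only actual number in this assay for the series; the other entry is a limit (the limit of > 100000 nM in this assay, at which 1 of the 2 values shown sits). Among the compounds with values here, the single measured step, an at least 12-fold lower number from compound 1 to compound 2 (1.08 log units; beyond the scatter), shows a large shift accompanying the exchange of iodo for methyl on the aromatic carbon of the aryl ketone.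

Compound 3 `CCc1ccc(C(=O)/C=C/c2ccc3c(c2)B(O)OC3)cc1` differs from compound 2 by methyl in place of hydrogen on a saturated chain carbon bound to an aromatic carbon. Within the data shown here, only one measured step exists, an at least 12-fold lower number from compound 1 to compound 2 (1.08 log units; beyond the scatter), and it concerns a halogen-to-methyl exchange, not a lengthening of an alkyl chain already in place. Among the measured compounds shown here, no measured step reports the effect of going from methyl to ethyl. With nothing directly comparable, the expectation for compound 3 in this assay is a step no larger than the usual scatter, a 1.0-fold lower number from compound 2 to compound 3 (0.02 log units; within the scatter), with the range opened somewhat because the closest measured step was large. Compound 3 is therefore estimated at 8000 nM in this assay, within 2500 nM to 30000 nM.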

Compound 3, half-maximal inhibitory concentration: 8800 nM
The estimate for compound 3 lay 1.1-fold (0.04 log units) below the measured number; the range from low to high includes it.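

Going from methyl to ethyl in this assay gives a 1.1-fold higher number from compound 2 to compound 3 (0.03 log units; within the scatter) and so leaves the number within the scatter: at this place, on a saturated chain carbon bound to an aromatic carbon, the added methyl brings no measurable shift, which the earlier compounds could not show. Ethyl in place of iodo gives an at least 11-fold lower number from compound 1 to compound 3 (1.05 log units; beyond the scatter) and stands beside an at least 12-fold lower number from compound 1 to compound 2 (1.08 log units; beyond the scatter) as a second large step beyond the scatter, so the separation from compound 1 holds for both alkyl groups shown, with compounds 2 and 3 alike in this read-out. Both steps start from compound 1, whose entry is a limit and not a number, so their true size stays unfixed: the limit of > 100000 nM in this assay, at which 1 of the 3 values shown sits.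

Going by these compounds, whether the same lack of response continues beyond ethyl remains open, and a longer chain such as propyl or butyl, a branched isopropyl, or a chain ending in an amine or a carboxylic acid would test it. Also open, on these data alone, is whether the large step belongs to iodo alone or extends to chloro, fluoro or the unsubstituted aromatic carbon.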